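Working notes: compound 4 against the shared core

This account rests on a few compounds, and the source may have more. Where it says the series, first, only, none or still open, it means among the compounds named here.

The series shares one core. Compound 1 `CC(/C=N/Nc1ccc([N+](=O)[O-])cc1)=N\NC(=O)c1ccccc1N`, compound 2 `CC(/C=N/Nc1ccc([N+](=O)[O-])cc1)=N\NC(=O)c1ccccc1C` and compound 3 `CC(/C=N/Nc1ccc([N+](=O)[O-])cc1)=N\NC(=O)c1ccccc1Nc1ccccc1` have been run in a functional assay on cells (Splenocyte, Mus musculus, strain BALB/c) for inhibition, read by scintillation counting and thymidine incorporation, with a stated time of 72 h; a higher number here means a weaker inhibitor, a lower number a stronger inhibitor. In that assay compound 1 gives 4900 nM and compound 2 gives 6000 nM; for compound 3 the entry is "not determined" (no result reported). Within the data shown here, compound 2 stands highest of the two numbers known, with compound 1 nearest, but the step of a 1.2-fold higher number from compound 1 to compound 2 (0.09 log units; within the scatter) lies within the scatter, so no order between compounds 1 and 2 can be read from it. Compound 4 `CC(/C=N/Nc1ccc([N+](=O)[O-])cc1)=N\NC(=O)c1ccc(N(C)C)cc1` differs from compound 2 as follows: 4-(dimethylamino)phenyl in place of 2-methylphenyl on a carbonyl carbon. Among the measured compounds shown here, only the step from compound 1 to compound 2 bears on this change, and that step, a methyl in place of amino on an aromatic carbon, left the number unchanged within the scatter; the swap to 4-(dimethylamino)phenyl is a larger change for which no measured step exists. Without such a step, compound 4 is expected in this assay to give a number near that of compound 2, and no step beyond the scatter is expected: no change at the digits printed from compound 2 to compound 4 (within the scatter). Compound 4 is estimated at 6000 nM, with a range from 2000 nM to 18000 nM.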

Compound 4, half-maximal inhibitory concentration: > 12000 nM
Compound 4 gave a limit, no number; the forecaster's own chance of this, stated with the estimate: 10%; at least 2.0-fold (0.30 log units) between middle value and limit.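

In this assay compound 4 returns a limit of the assay and not a number: the limit of > 12000 nM in this assay, at which 1 of the 4 values shown sits.

Placing 4-(dimethylamino)phenyl on the carbonyl carbon gives an at least 2.4-fold higher number from compound 1 to compound 4 (0.38 log units; beyond the scatter), the first step in the series that clears the scatter, and it runs toward weaker inhibition. Among these compounds, the earlier change at this part of the molecule, methyl in place of amino on an aromatic carbon, gave only a 1.2-fold higher number from compound 1 to compound 2 (0.09 log units; within the scatter), so the number at this position had not yet been seen to respond, while the reading against the other neighbour, an at least 2.0-fold higher number from compound 2 to compound 4 (0.30 log units; that floor lies within the scatter), has a floor that does not by itself separate that pair.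

Open, as far as these compounds go, is how far past the limit compound 4 really lies, and whether the step follows the dimethylamino group itself or where it stands on the ring, a question that 2-(dimethylamino)phenyl or 4-methylphenyl on the same carbonyl carbon would separate. Also open, from the compounds shown here alone, is how an unsubstituted phenyl, or a phenyl carrying a carboxylic acid, would read in this assay against the shared core.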